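The compounds below may be only part of what the source reports. "The series", "measured", "known", "first", "only" and "open" are said of these compounds alone.

Values so far in an ADME assay on microsomes from liver (Mus musculus) for metabolic stability, read by LC-MS, with NADPH named in the record, with a stated time of 60 min, tested at 1 uM, in the absence of a further agent; a higher number here means that more of the compound is left, a lower number that less of the compound is left:
compound 1 `COc1ccc(-c2c(C)nc3c(N4CC[C@@H](NC(=O)C(F)(F)F)C4)cc(C)nn23)cc1OC`: > 95%
compound 2 `COc1ccc(-c2c(C)nc3c(N4CC[C@@H](NC(=O)OC5CCCCC5)C4)cc(C)nn23)cc1OC`: > 95%
compound 3 `COc1ccc(-c2c(C)nc3c(N4CC[C@@H](SC(C)=O)C4)cc(C)nn23)cc1OC`: > 95%

Each entry is a limit of the assay and not a number. Compound 3 gives > 95%, which is a limit only. The wider picture is the limit of > 95% in this assay, at which 3 of the 3 values shown sit.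

Next is compound 4 `COc1ccc(-c2c(C)nc3c(N4CC[C@@H](N=[N+]=[N-])C4)cc(C)nn23)cc1OC`, not yet measured. The change is azido in place of acetylsulfanyl on a saturated ring carbon of a five-membered non-aromatic ring with 1 nitrogen: azido in place of acetylsulfanyl on a saturated ring carbon.

Two measured steps alter the group on this carbon: a step that the two limits leave unreadable from compound 1 to compound 3 and a step that the two limits leave unreadable from compound 2 to compound 3. Neither has a readable size, and azido has not been measured in this series. Across these dissimilar groups, no step has left the limit, and no measured compound goes against this. In this assay no change beyond the scatter is therefore expected, and no direction is predicted. The expected step is a number at least 2 percentage points lower from compound 3 to compound 4 (that floor lies within the scatter). For compound 4 the estimated value is 93%, with an expected range from 75% to 100%.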

Compound 4, percent of the compound remaining: > 95%
Compound 4: no number, only a limit (the forecaster's own chance of this, stated with the estimate: 55%); at least 2 percentage points between middle value and limit.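

In this assay compound 1, compound 2, compound 3 and compound 4 all stand at the same limit, and no new step can be read among them. Left open is how far these groups on the saturated ring carbon actually differ in percent of compound remaining, and which change, if any, would bring a value off the limit.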